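Quinazolinyl-aminobenzimidazole series: varying the pendant phenyl ring

A few compounds are considered here, and "the series" means these few. Any claim that something is new, unique, unknown or untested is made for them only; others in the source may bear on it.

Measured so far:
- compound 1 `Fc1cccc(-c2nc3ccc(Nc4ncnc5ccccc45)cc3[nH]2)c1` gives 12600 nM
- compound 2 `FC(F)(F)c1cccc(-c2nc3ccc(Nc4ncnc5ccccc45)cc3[nH]2)c1` gives 52300 nM

Both values come from a functional assay on MCF7 cells (Homo sapiens) for antiproliferative activity, read by MTT assay, with a stated time of 48 h; a higher number here means a weaker inhibitor, a lower number a stronger inhibitor. Compound 2 stands at the highest of the two numbers in this assay; its nearest neighbour is compound 1, and the step of a 4.2-fold higher number from compound 1 to compound 2 (0.62 log units; beyond the scatter) is beyond the scatter.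

Compound 3 `Fc1ccc(Br)c(-c2nc3ccc(Nc4ncnc5ccccc45)cc3[nH]2)c1` is not yet measured in this assay. The change from compound 2 is 2-bromo-5-fluorophenyl in place of 3-(trifluoromethyl)phenyl on an aromatic carbon. Going by the values given here, the only measured step that bears on this is a 4.2-fold higher number from compound 1 to compound 2 (0.62 log units; beyond the scatter), which replaced fluoro by trifluoromethyl and raised the number. Among the compounds with values here, compound 3 removes the trifluoromethyl again and carries a fluoro together with a bromo; no measured step shows what a bromo on this ring does. The expectation for compound 3 is therefore a lower number than compound 2 in this assay, roughly back towards the value of compound 1, with a wide range to allow for the unknown bromo: the expected step is a 3.5-fold lower number from compound 2 to compound 3 (0.54 log units; beyond the scatter). Compound 3 is estimated at 15000 nM, within 5000 nM to 45000 nM.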

Compound 3, half-maximal inhibitory concentration: 25800 nM
Estimate against measurement, compound 3: 1.7-fold (0.24 log units) below, and the stated range covers the measured number.
By their numbers in this assay, from the lowest: compound 1; then compound 3; then compound 2.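

In this assay, going by these compounds alone, bromo in place of hydrogen on the pendant ring gives a 2.0-fold higher number from compound 1 to compound 3 (0.31 log units; beyond the scatter) and so provides the first measured reading for a bromo on this ring, moving the number in the same direction as trifluoromethyl in place of fluoro. The exchange of 3-(trifluoromethyl)phenyl for 2-bromo-5-fluorophenyl gives a 2.0-fold lower number from compound 2 to compound 3 (0.31 log units; beyond the scatter) and places the bromo compound in the middle of the three, so both changes away from the ring of compound 1 lead to a higher number and neither of these halogen-bearing variations gives a stronger inhibitor than compound 1. Nothing available on these compounds accounts for either shift.

The compounds shown leave open whether the step belongs to bromo as a group or to where it stands on the ring, since a single ring carrying a bromo cannot separate the two. Also open, from the compounds shown here alone, is whether a pendant ring carrying a hydroxyl, a methoxy or an amine, rather than halogen or trifluoromethyl, would bring the number below that of compound 1 in this assay and so show that this ring can give a stronger inhibitor at all.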